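This account rests on a few compounds, and the source may have more. Where it says the series, first, only, none or still open, it means among the compounds named here.

Compound 1 `CC(C)(C)c1ccc(-c2ccc(-c3ccc(C(=N)N)cc3)o2)cc1`, compound 2 `N=C(N)c1ccc(-c2ccc(-c3ccc(Br)cc3)o2)cc1` and compound 3 `N=C(N)c1ccc(-c2ccc(-c3cccc([N+](=O)[O-])c3)o2)cc1` share a core and differ only in the outer aromatic ring attached to it. In a functional assay on T47D cells (Homo sapiens) for cytotoxicity, read by MTT assay, with a stated time of 96 h (a higher number here means a weaker inhibitor, a lower number a stronger inhibitor), compound 1 gives 3600 nM, compound 2 gives 2400 nM and compound 3 gives 3300 nM; compound 2 has the lowest number of the three, yet all three lie within the scatter of one another. For the measured compounds named here, the only single change measured, a 1.5-fold lower number from compound 1 to compound 2 (0.18 log units; within the scatter), stayed within the scatter. Compound 4 `N=C(N)c1ccc(-c2ccc(-c3cccc(F)c3)o2)cc1` is not yet measured; it differs from compound 2 by 3-fluorophenyl in place of 4-bromophenyl on an aromatic carbon. Because a 1.5-fold lower number from compound 1 to compound 2 (0.18 log units; within the scatter) moved the number so little, the step of a 1.3-fold higher number from compound 2 to compound 4 (0.10 log units; within the scatter) is expected to show no shift beyond the scatter either. Compound 4 is therefore estimated at 3000 nM, with a likely range of 1500 nM to 6000 nM.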

Compound 4, half-maximal inhibitory concentration: 2800 nM
Beside the measured number, compound 4's estimate is 1.1-fold (0.03 log units) above it; low and high end bracket the measured number.
By their numbers in this assay, from the lowest: compounds 2, 4, 3 and 1 (each within the scatter of the next).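

In this assay, 3-fluorophenyl in place of 4-bromophenyl changes both the halogen and its place on the outer ring, yet the result is a 1.2-fold higher number from compound 2 to compound 4 (0.07 log units; within the scatter), and this position tolerates that double change. Fluoro in place of nitro on an aromatic carbon gives a 1.2-fold lower number from compound 3 to compound 4 (0.07 log units; within the scatter), so swapping this nitro group for a halogen also leaves the number within the scatter. No evidence on hand accounts for this. From the compounds shown here alone, whether an amine or a carboxylic acid on the outer ring would move the number beyond the scatter remains open.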